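Sulfanyl-Linked Methoxyphenyl in Place of a Fluorobenzylamine

The source may report more compounds than this note shows. Statements on the series, on what has been measured and on what is new or still open speak of the compounds shown alone.

Compound 3 `Nc1cc(N)c2nc(-c3ccccc3)c(NCc3ccc(F)cc3)nc2c1` gives 8910 nM in a functional assay on UACC-257 cells (Homo sapiens) for inhibition, read by sulforhodamine B assay, with a stated time of 48 h (on this read-out higher numbers stand for lower toxicity in this test and lower numbers for higher toxicity in this test), the lowest of the two numbers shown. Compound 2 `COc1ccc(CNc2nc3cc(N)cc(N)c3nc2-c2ccccc2)cc1OC` gives 55000 nM in this assay. Compound 1 `Nc1cc(N)c2nc(-c3ccccc3)c(Oc3ccc(Cl)c(Cl)c3)nc2c1` reaches only a limit, < 100000 nM in this assay. Hence a step that the limit leaves unreadable from compound 1 to compound 3, as the limit of < 100000 nM in this assay, at which 1 of the 3 values shown sits, shows. The readable change, a 6.2-fold lower number from compound 2 to compound 3 (0.79 log units; beyond the scatter), is modest. Compound 4 `COc1ccc(Sc2nc3cc(N)cc(N)c3nc2-c2ccccc2)cc1` carries (4-methoxyphenyl)sulfanyl in place of (4-fluorobenzyl)amino on an aromatic carbon. Compound 2 gives a higher number than compound 3, and compound 1 with its 3,4-dichlorophenoxy group sits at its limit, so a rise is expected. The step of a 3.4-fold higher number from compound 3 to compound 4 (0.53 log units; beyond the scatter) is expected to be modest and upward. Compound 4 is estimated at about 30000 nM, between 8000 nM and 100000 nM.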

Compound 4, concentration lethal to 50% of the cells: < 100000 nM
Compound 4: a limit, no number; the forecaster's own chance of this, stated with the estimate: 30%; the middle value does not contradict the limit.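

In this assay compound 4 gives < 100000 nM, a limit and not a number, so its steps from compound 3 and compound 1 cannot be read. The compounds shown leave open how (4-methoxyphenyl)sulfanyl compares with (4-fluorobenzyl)amino on the shared core.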